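Fluoro on the Aromatic Ring of Compound 3

This account rests on a few compounds, and the source may have more. Where it says the series, first, only, none or still open, it means among the compounds named here.

Three compounds share one core and were measured in a functional assay on WiDr cells (Homo sapiens) for inhibition, read by sulforhodamine B assay, with a stated time of 48 h; on this read-out lower numbers stand for stronger inhibition of growth and higher numbers for weaker inhibition of growth. Compound 1, `COC(=O)[C@@]1(C)CCC=C2[C@@H]1CC[C@@H](C)[C@]2(C)Cc1c[nH]c2ccccc12`, gives 8700 nM in this assay. Compound 2, `COC(=O)[C@@]1(C)CCC=C2[C@@H]1CC[C@@H](C)[C@]2(C)Cc1c[nH]c2ccc(OC)cc12`, carries a methoxy group on an aromatic carbon and gives 5700 nM; the step of a 1.5-fold lower number from compound 1 to compound 2 (0.18 log units; within the scatter) is small. Compound 3, `COC(=O)[C@@]1(C)CCC=C2[C@@H]1CC[C@@H](C)[C@]2(C)Cc1c(C)[nH]c2ccccc12`, carries a methyl group and gives 19000 nM; the step of a 2.2-fold higher number from compound 1 to compound 3 (0.34 log units; beyond the scatter) is modest. Compound 3 thus stands at the highest number of the three, with compound 1 nearest and compound 2 furthest.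

Compound 4, `COC(=O)[C@@]1(C)CCC=C2[C@@H]1CC[C@@H](C)[C@]2(C)Cc1c(C)[nH]c2ccc(F)cc12`, differs from compound 3 in one place: fluoro in place of hydrogen on an aromatic carbon. Among the measured compounds shown here, the only measured step that bears on a substituent entering an aromatic carbon of this ring is the step from compound 1 to compound 2, which stayed within the scatter. No step beyond the scatter is therefore expected in this assay, and compound 4 is expected to give 16000 nM, between 7000 nM and 36000 nM, a step of a 1.2-fold lower number from compound 3 to compound 4 (0.07 log units; within the scatter) from compound 3.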

Compound 4, concentration for 50% growth inhibition: 17000 nM
Estimate against measurement, compound 4: 1.1-fold (0.03 log units) below; measured number inside the range.
By their numbers in this assay, from the lowest: compounds 2, 1, 4 and 3 (each within the scatter of the next, the first and the last beyond it).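

In this assay, fluoro in place of hydrogen on this aromatic carbon, meta to a fused ring and para to a fused ring, leaves the number of compound 3 within the scatter (a 1.1-fold lower number from compound 3 to compound 4 (0.05 log units; within the scatter)). The earlier compounds showed such a small step only for methoxy on compound 1 (a 1.5-fold lower number from compound 1 to compound 2 (0.18 log units; within the scatter)); this result adds a second, much smaller substituent and shows the same outcome on the methyl-bearing compound 3, so the two listed substitutions at this carbon both stay within the scatter. Nothing given here explains why the number hardly moves.

The compounds shown leave open whether an amine, a carboxylic acid or a longer chain on this aromatic carbon would give a step beyond the scatter. They also leave open how fluoro would act on compound 1, which lacks the methyl group.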